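The source may hold more compounds than are shown below. What is called first, only, known or untested is meant among the compounds shown, and "the series" means these compounds.

Of the compounds shown here, three sharing one core have been tested in a functional assay on RAW264.7 cells (Mus musculus) for inhibition, read by Griess assay, with stated times of 3 h and 24 h; on this read-out lower numbers stand for stronger inhibition and higher numbers for weaker inhibition. Compound 1 `C=C1CC[C@H]2[C@@](C)(CCC(=O)N[C@@]2(C)CO)[C@@H]1/C=C/C1=CCOC1=O` gives > 50000 nM, which is a limit and not a number. Compound 3 `C=C1CC[C@H]2[C@@](C)(CCC(=O)N[C@@]2(C)COC(=O)[C@@H]2CCCN2)[C@@H]1/C=C/C1=CCOC1=O` gives > 50000 nM, again only a limit. Compound 2 `C=C1CC[C@H]2[C@@](C)(CCC(=O)N[C@@]2(C)COC(=O)c2ccc([N+](=O)[O-])cc2)[C@@H]1/C=C/C1=CCOC1=O` gives a readable 33500 nM. Compound 3 therefore sits at the limit of > 50000 nM in this assay, at which 2 of the 3 values shown sit, with no true potency known.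

Compound 4 `C=C1CC[C@H]2[C@@](C)(CCC(=O)N[C@@]2(C)COC(=O)CCCC[C@@H]2CCSS2)[C@@H]1/C=C/C1=CCOC1=O` differs from compound 3 on the carbonyl carbon: a group of 9 heavy atoms (7 carbon, 2 sulfur; one five-membered non-aromatic ring with 2 hetero atoms) in place of a group of 5 heavy atoms (4 carbon, 1 nitrogen; one five-membered non-aromatic ring with 1 hetero atom), on a carbonyl carbon.

The measured steps that bear on this change are small or unreadable. Adding (4-nitrophenyl)carbonyl gave an at least 1.4-fold lower number from compound 1 to compound 2 (0.17 log units; that floor lies within the scatter), and replacing 4-nitrophenyl with pyrrolidin-2-yl gave an at least 1.4-fold higher number from compound 2 to compound 3 (0.17 log units; that floor lies within the scatter). Adding (pyrrolidin-2-yl)carbonyl gave a step that the two limits leave unreadable from compound 1 to compound 3. None of these supports a large move. For the measured compounds named here, compound 2 at 33500 nM holds the only readable value. A modest shift towards lower numbers is the most that can be expected, and compound 4 may stay at the limit.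

The expected change is an at least 1.5-fold lower number from compound 3 to compound 4 (0.19 log units; that floor lies within the scatter). Compound 4 is estimated at 32000 nM, with an expected range from 12000 nM to 60000 nM.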

Compound 4, half-maximal inhibitory concentration: 22400 nM
For compound 4 the middle estimate is 1.4-fold (0.15 log units) above the measured one; low and high end bracket the measured number.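

In this assay, the group with the five-membered ring holding two sulfur atoms gives an at least 2.2-fold lower number from compound 3 to compound 4 (0.34 log units; beyond the scatter) and an at least 2.2-fold lower number from compound 1 to compound 4 (0.34 log units; beyond the scatter), the first steps at this position shown to lie beyond the scatter. Both sizes are only floors, since compound 1 and compound 3 each give a limit and not a number: the limit of > 50000 nM in this assay, at which 2 of the 4 values shown sit. Exchanging 4-nitrophenyl for this group gives a 1.5-fold lower number from compound 2 to compound 4 (0.17 log units; within the scatter), so on this read-out the two groups cannot be told apart.

Whether the sulfur-containing ring or the chain carrying it accounts for the step remains open, and a plain hexyl chain on the same carbonyl carbon would help separate the two. Going by these compounds, how an amine or a carboxylic acid at the end of that chain would read also remains unknown.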